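Removing the carboxy group from compound 2

The source may hold more compounds than are shown below. What is called first, only, known or untested is meant among the compounds shown, and "the series" means these compounds.

The series is followed in an assay on CHO cells for displacement of a labelled ligand from adenosine receptor A1 (Homo sapiens), read by scintillation counting, with a stated time of 60 min, tested at 10 uM; on this read-out higher numbers stand for more inhibition at the one concentration tested (going by the name of the read-out) and lower numbers for less inhibition. Compound 1, `COCCNC(=O)c1cc2cccc(OC)c2oc1=N`, gives > 70%, a value that is a limit of the assay rather than a number. Compound 3, `COc1cccc2cc(C(=O)NCCCOCCCCOCCCNC(=O)c3cc4cccc(OC)c4oc3=N)c(=N)oc12`, gives 30%. Compound 2, `COc1cccc2cc(C(=O)N[C@@H](CO)C(=O)O)c(=O)oc12`, gives 12%, the lowest of the two numbers shown; the nearest number, that of compound 3, is higher by a gap beyond the scatter. Compound 4, `COc1cccc2cc(C(=O)NCCO)c(=O)oc12`, has not yet been measured in this assay. It differs from compound 2 in one place: hydrogen in place of carboxy on a saturated chain carbon bound to an amide-type nitrogen and a saturated chain carbon. For the measured compounds named here, no pair of measured compounds differing in a single place is available, so the size of this step cannot be read from measured values. On the shown numbers, compound 4 is expected to sit somewhat above compound 2, with a step of a number 13 percentage points higher from compound 2 to compound 4 (beyond the scatter) in this assay, though the change could also stay within the scatter. The estimate for compound 4 in this assay is 25%, within a range from 5% to 50%.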

Compound 4, a percentage reported as inhibition, at one concentration (the size of the read-out at that concentration, not a potency): 12%
Compound 4: the middle estimate sits 13 percentage points above what was measured; measured number inside the range.
By their numbers in this assay, from the lowest: compounds 2 and 4 (each within the scatter of the next); then compound 3. At a limit, above all of these: compound 1.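

In this assay, for the compounds shown here, the replacement reads no change at the digits printed from compound 2 to compound 4 (within the scatter), the first step between measured compounds that differ in one place. It shows that, on the saturated chain carbon bound to an amide-type nitrogen and a saturated chain carbon, the carboxy group can give way to hydrogen with no visible effect on this read-out. The 1-carboxy-2-hydroxyethyl and 2-hydroxyethyl groups therefore cannot be told apart at the one concentration tested.

Going by these compounds, it remains open whether an amine or a longer chain in place of the 2-hydroxyethyl group would move the number at all. Compound 1, with > 70%, stands at a limit and not at a number, and no step in one place links it to any other compound shown: the limit of > 70% in this assay, at which 1 of the 4 values shown sits.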